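This account rests on a few compounds, and the source may have more. Where it says the series, first, only, none or still open, it means among the compounds named here.

Measured so far in an assay on membranes from brain for binding affinity to adenosine receptor A1 (Rattus norvegicus), read by radioligand binding, tested at 20 uM; a lower number here means less inhibition, a higher number more inhibition at the concentration tested (going by the name of the read-out):
Compound 1, `Cn1c(=O)[nH]c2c(cnn2-c2cc(Cl)ccc2Cl)c1=N`, gives 1%.
Compound 2, `CCCn1ncc2c(=N)n(C)c(=O)[nH]c21`, gives 5%.
Compound 3, `Cn1c(=O)[nH]c2c(cnn2-c2cccc(Br)c2)c1=N`, gives 40%.

Compound 3 stands highest of the three: its number lies above that of compound 2 and that of compound 1 by gaps well beyond the scatter of repeated measurements. Compound 4, `Cn1c(=O)[nH]c2c(cnn2-c2cccc(N)c2)c1=N`, has not yet been measured. It differs from compound 3 in one place: amino in place of bromo on an aromatic carbon. Among the compounds with values here, no pair of measured compounds differs by such a single change, so nothing here shows directly how this swap shifts the number; compound 1 and compound 3 both carry halogens on the ring yet sit far apart. In this assay the step from compound 3 to compound 4 is expected to be a drop, a number 20 percentage points lower from compound 3 to compound 4 (beyond the scatter), beyond the scatter. Compound 4 is therefore estimated at 20%, within a range from 0% to 50%.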

Compound 4, a percentage reported as inhibition, at one concentration (the size of the read-out at that concentration, not a potency): 0%
Compound 4: the middle estimate sits 20 percentage points above what was measured; the range from low to high includes it.
By their numbers in this assay, from the lowest: compounds 4, 1 and 2 (each within the scatter of the next); then compound 3.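

In this assay, within the data shown here, the swap of bromo for amino on this aromatic carbon brings a number 40 percentage points lower from compound 3 to compound 4 (beyond the scatter) and is the first single change seen at this place. With the rest of the molecule unchanged, this one group can therefore decide much of the reading. Nothing measured here explains the drop.

On these data alone, whether the drop comes from losing bromo or from gaining amino remains open, and a methyl, a methoxy or a plain hydrogen at this place would help separate the two. One step also cannot show whether the swap acts alike on other substitution patterns.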